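The source may hold more compounds than are shown below. What is called first, only, known or untested is meant among the compounds shown, and "the series" means these compounds.

In an ADME assay on microsomes from liver (Homo sapiens) for metabolic stability, read by LC-MS, with a stated time of 10 min, tested at 0.5 uM (a higher number here means that more of the compound is left, a lower number that less of the compound is left), compound 2 `c1ccc2c(c1)CN[C@@H](CN(CC[C@H]1CCCNC1)[C@H]1CCCc3cccnc31)C2` gives 93%. Compound 1 `c1ccc2c(c1)CN[C@@H](CN(CC1CCNCC1)[C@H]1CCCc3cccnc31)C2` gives 86%. These two numbers lie within the scatter of each other, so no order can be drawn between them. Compound 3 `CN1CCN(CCCN(C[C@H]2Cc3ccccc3CN2)[C@H]2CCCc3cccnc32)CC1` keeps the shared core, and the difference from compound 2 is (4-methylpiperazin-1-yl)methyl in place of piperidin-3-yl on a saturated chain carbon, two bonds along the chain from an amine nitrogen. In words, this is (4-methylpiperazin-1-yl)methyl in place of piperidin-3-yl on a saturated chain carbon, two bonds along the chain from an amine nitrogen.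

Within the data shown here, only one measured step bears on this change, and only indirectly. It is a number 7 percentage points higher from compound 1 to compound 2 (within the scatter), which also altered the chain on the amine nitrogen and stayed within the scatter. That step does not include the (4-methylpiperazin-1-yl)methyl group, so the data offer no direct measure of what this group does. From that single step, no change beyond the scatter is expected in this assay, with a slight lean downward allowed for the untested group. The estimated step is a number 8 percentage points lower from compound 2 to compound 3 (within the scatter). For compound 3 the expected value is 85%, with an estimated range of 68% to 97%.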

Compound 3, percent of the compound remaining: 72%
For compound 3 the middle estimate is 13 percentage points above the measured one; the measured number falls inside the stated range.
By their numbers in this assay, from the lowest: compound 3; then compounds 1 and 2 (each within the scatter of the next).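

In this assay, among these compounds, (4-methylpiperazin-1-yl)methyl in place of piperidin-3-yl on a saturated chain carbon, two bonds along the chain from an amine nitrogen, brings a number 21 percentage points lower from compound 2 to compound 3 (beyond the scatter) and gives the first step in this set that clears the scatter. The same holds against the other earlier compound, since 2-(4-methylpiperazin-1-yl)ethyl in place of piperidin-4-yl brings a number 14 percentage points lower from compound 1 to compound 3 (beyond the scatter), whereas the step between the two piperidine compounds, a number 7 percentage points higher from compound 1 to compound 2 (within the scatter), did not separate them, so this position tolerated the exchange of one piperidine attachment for another but responded to the methylpiperazine side chain. No measurement available here accounts for the lower number.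

The change replaces a ring with one hetero atom and one hydrogen-bond donor by a ring with two hetero atoms and no donors, and it also adds a methyl group and alters the reach of the chain, so the compounds shown do not tell which of these differences carries the step. From the compounds shown here alone, a plain piperazin-1-yl or a 1-methylpiperidin-3-yl group on the same chain would separate the ring nitrogen from the methyl group, and whether the step holds on any other core remains open.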